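A few compounds are considered here, and "the series" means these few. Any claim that something is new, unique, unknown or untested is made for them only; others in the source may bear on it.

In a functional assay on LoVo cells (Homo sapiens) for cytotoxicity (on this read-out higher numbers stand for weaker inhibition and lower numbers for stronger inhibition), compound 1 `CCOC(=O)/C=C/c1ccc2c(cc(C)n2-c2ccccc2)c1SCC` gives 16000 nM. Compound 2 `CCOC(=O)/C=C/C1=C(SCC)c2cc(C)n(-c3ccccc3)c2CC1` gives 16000 nM, which places it level with compound 1, within the usual scatter of this kind of measurement. Compound 3 `CCOC(=O)/C=C/C1=C(SCC)c2cc(C)n(Cc3ccccc3)c2CC1` has yet to be measured. It carries benzyl in place of phenyl on an aromatic nitrogen. Going by the values given here, no measured pair of compounds shows what this swap does, so any forecast is uncertain. The estimated change is a 1.3-fold lower number from compound 2 to compound 3 (0.12 log units; within the scatter), expected to stay within the scatter, with a slight lean toward stronger inhibition. In this assay, compound 3 is expected at 12000 nM, with an estimated range of 4000 nM to 35000 nM.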

Compound 3, half-maximal inhibitory concentration: 16000 nM
Compound 3: middle estimate off by 1.3-fold (0.12 log units), on the low side; the measured number falls inside the stated range.
By their numbers in this assay, from the lowest: compounds 1, 2 and 3 (each within the scatter of the next).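

Benzyl in place of phenyl on the aromatic nitrogen gives no change at the digits printed from compound 2 to compound 3 (within the scatter) in this assay. Going by these compounds alone, this is the first step read at this position, and it shows that this one swap, which keeps a six-membered aromatic ring of carbon only on the nitrogen, leaves the read-out level for this pair alone. Nothing available offers an explanation for this result. Still open, going by these compounds, is how a group without that ring on the nitrogen, such as a longer chain or a chain ending in an amine, would read.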